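Meta cyano analogue: expected microsomal clearance from three measured sulfonamides

The compounds below may be only part of what the source reports. "The series", "measured", "known", "first", "only" and "open" are said of these compounds alone.

Compound 1, `CCn1c([C@@H](C)NS(=O)(=O)c2ccc(Cl)cc2)nc2ccc(C(F)(F)F)cc21`, in an ADME assay (liver) for metabolic stability, with Liver microsome (Homo sapiens) as the target, read by LC-MS, using microsomes and NADPH, with a stated time of 5 min, at 37 degrees C; a lower number here means slower removal, a higher number faster removal of the compound: > 100 mL.min-1.g-1, a limit of the assay and not a number.
Compound 2, `CCn1c([C@@H](C)NS(=O)(=O)c2ccc(C#N)cc2)nc2ccc(C(F)(F)F)cc21`, in this assay: 34 mL.min-1.g-1.
Compound 3, `CCn1c([C@@H](C)NS(=O)(=O)c2cccc(Cl)c2)nc2ccc(C(F)(F)F)cc21`, in this assay: > 100 mL.min-1.g-1, again a limit of the assay and not a number.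

Compound 1 and compound 3 share all their atoms, joined differently: 3-chlorophenyl in place of 4-chlorophenyl on a sulfonyl sulfur. Their values do not separate them, since a step that the two limits leave unreadable from compound 1 to compound 3 because of the limit of > 100 mL.min-1.g-1 in this assay, at which 2 of the 3 values shown sit. Compound 2 does stand apart: the change cyano in place of chloro on an aromatic carbon gives an at least 2.9-fold lower number from compound 1 to compound 2 (0.46 log units; beyond the scatter), and in the other direction an at least 2.9-fold higher number from compound 2 to compound 3 (0.46 log units; beyond the scatter).

Compound 4, `CCn1c([C@@H](C)NS(=O)(=O)c2cccc(C#N)c2)nc2ccc(C(F)(F)F)cc21`, has not yet been measured in this assay. It differs from compound 3 by cyano in place of chloro on an aromatic carbon. For the measured compounds named here, this is the same kind of change as the one from compound 1 to compound 2, where the cyano sits para to a large group, whereas in compound 4 it sits meta to a large group. Going by the values given here, the only measured example of this change is the step from compound 1 to compound 2, and the starting value for compound 3 is a limit, so the expectation for compound 4 rests on one step only. Compound 4 is expected to move by an at least 2.2-fold lower number from compound 3 to compound 4 (0.34 log units; beyond the scatter). Compound 4 is estimated at 45 mL.min-1.g-1, with a range from 18 mL.min-1.g-1 to 100 mL.min-1.g-1.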

Compound 4, intrinsic clearance in microsomes: > 100 mL.min-1.g-1
Compound 4: a limit, no number (the forecaster's own chance of this, stated with the estimate: 25%); at least 2.2-fold (0.34 log units) between middle value and limit.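

Compound 4 gives > 100 mL.min-1.g-1 in this assay, a limit of the assay and not a number. For the compounds shown here, the swap of chloro for cyano that gave an at least 2.9-fold lower number from compound 1 to compound 2 (0.46 log units; beyond the scatter) on the 4-chlorophenyl compound thus did not bring the 3-chlorophenyl compound to a readable number, and the one step that can be read here is an at least 2.9-fold higher number from compound 2 to compound 4 (0.46 log units; beyond the scatter), so with the shared core unchanged, 3-cyanophenyl and 4-cyanophenyl do not behave alike in this assay. This does not show that the swap has no effect on compound 3, since the steps from compound 3 to compound 4 and from compound 1 to compound 4 cannot be read, and any real change there stays hidden because of this: the limit of > 100 mL.min-1.g-1 in this assay, at which 3 of the 4 values shown sit.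

On these data alone, compound 2 is the only one of the four with a number, 34 mL.min-1.g-1, so the account of the swap rests on a single readable case, and it remains open whether the 4-cyanophenyl result would hold on any other core. Also open, as far as these compounds go, is how a methoxy group, an amine or a carboxylic acid on the same phenyl ring, or a longer chain in place of the ethyl group, would fare in this assay.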